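The source may report more compounds than this note shows. Statements on the series, on what has been measured and on what is new or still open speak of the compounds shown alone.

Measured compounds:
Compound 1 `Cc1nnc(SCc2cc(=O)c3cc(Cl)ccc3o2)o1`; in a functional assay on MDA-MB-435S cells (Homo sapiens) for cytotoxicity, read by MTT assay, with a stated time of 72 h (a higher number here means a weaker inhibitor, a lower number a stronger inhibitor), compound 1 gives only the limit > 25000 nM.
Compound 2 `Cc1nnc(SCc2cc(=O)c3ccccc3o2)o1`; in this assay compound 2 gives only the limit > 25000 nM.
Compound 3 `Nc1nnc(SCc2cc(=O)c3ccccc3o2)s1`; in this assay compound 3 gives only the limit > 25000 nM.

Compound 3 therefore stands with the other two at the limit of > 25000 nM in this assay, at which 3 of the 3 values shown sit, and nothing separates the three. The change from compound 3 to compound 4 `Nc1nnc(SCc2cc(=O)c3cc(Cl)ccc3o2)s1` is chloro in place of hydrogen on an aromatic carbon. The step that bears on it is a step that the two limits leave unreadable from compound 1 to compound 2, the same exchange run the other way on the other core; the step that the two limits leave unreadable from compound 2 to compound 3 is likewise unreadable. No step beyond the scatter is expected in this assay, and a limit rather than a number is the likely outcome. Compound 4 is expected at 30000 nM, range 10000 nM to 100000 nM, an expected step that the limit leaves unreadable from compound 3 to compound 4.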

Compound 4, half-maximal inhibitory concentration: > 25000 nM
Compound 4 was reported as a limit; the forecaster's own chance of this, stated with the estimate: 85%; the middle value lies beyond the limit too.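

Among the compounds shown here, compound 4 gives only a limit, so no step from compound 3 or from compound 1 to compound 4 can be read: the limit of > 25000 nM in this assay, at which 4 of the 4 values shown sit. The compounds shown leave open whether any member of this series gives a number rather than a limit in this assay at all.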